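The compounds below may be only part of what the source reports. "The series", "measured", "known", "first", "only" and "open" are said of these compounds alone.

Of the compounds shown here, three have been tested in a functional assay on the whole organism with Rattus norvegicus as the target, at a dose of 100 mg/kg; a lower number here means less inhibition, a higher number more inhibition at the dose given (going by the name of the read-out). Compound 1, `N/C(S)=N/CCCCn1nc(-c2ccccc2)ccc1=O`, gives 72%. Compound 2, `C/N=C(\S)NCCCCCCn1nc(-c2ccccc2)ccc1=O`, gives 22.2%. Compound 3, `C/N=C(\NC#N)NCCCCn1nc(-c2ccccc2)ccc1=O`, gives 79%, the highest of the three numbers, although its gap to compound 1 is within the scatter; the step of a number 56.8 percentage points higher from compound 2 to compound 3 (beyond the scatter) is large and beyond the scatter. The step of a number 7 percentage points higher from compound 1 to compound 3 (within the scatter) is small, whereas the step of a number 49.8 percentage points lower from compound 1 to compound 2 (beyond the scatter) is large.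

Compound 4, `C/N=C(\S)NCCCn1nc(-c2ccccc2)ccc1=O`, is not yet measured. It differs from compound 3 in one place: a group of 5 heavy atoms (2 carbon, 2 nitrogen, 1 sulfur; no ring) in place of a group of 8 heavy atoms (4 carbon, 4 nitrogen; no ring), on a saturated chain carbon, three bonds along the chain from an aromatic nitrogen. Among the compounds with values here, the entering group is the one carried by compound 2, and it now sits closer along the chain than in compound 3. Within the data shown here, the steps that bear on this change are the large drop a number 49.8 percentage points lower from compound 1 to compound 2 (beyond the scatter) and the large rise a number 56.8 percentage points higher from compound 2 to compound 3 (beyond the scatter), both of which put the methyl-bearing thiourea group at the low end. Among the measured compounds shown here, a drop is therefore expected, though the shorter chain in compound 4 has no direct precedent here, so the estimated step of a number 39 percentage points lower from compound 3 to compound 4 (beyond the scatter) is given with a wide range. Compound 4 is expected to give 40%, between 15% and 68%.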

Compound 4, a percentage reported as inhibition, in the whole organism at one dose (the size of the read-out at that dose, not a potency): 38.9%
Compound 4: middle estimate off by 1.1 percentage points, on the high side; the range from low to high includes it.
By their numbers in this assay, from the lowest: compound 2; then compound 4; then compounds 1 and 3 (each within the scatter of the next).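

Keeping the methyl-bearing thiourea group and changing only the chain gives a number 16.7 percentage points higher from compound 2 to compound 4 (beyond the scatter), so chain length alone moves the number, and here the chain that ends three bonds along from the aromatic nitrogen gives the higher result. That modest step still leaves compound 4 well short of the two best compounds, with a number 40.1 percentage points lower from compound 3 to compound 4 (beyond the scatter) and a number 33.1 percentage points lower from compound 1 to compound 4 (beyond the scatter), so the shorter chain does not recover what they show. Nothing available explains these steps.

Going by these compounds, each of those two larger steps changes the chain and the end group together, so their separate shares remain unknown. Also open, on these data alone, is how a urea in place of the thiourea, or an ethyl group in place of the methyl, would behave on either chain.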